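Series notes: from compound 2 to compound 4

The source may report more compounds than this note shows. Statements on the series, on what has been measured and on what is new or still open speak of the compounds shown alone.

Measured in a physicochemical assay for lipophilicity, measured as octanol-water partition; on this read-out higher numbers stand for higher lipophilicity and lower numbers for lower lipophilicity
- compound 1 `C/C(=N\NC(=O)COc1cccc2ccccc12)c1ccc(C#N)cc1Br` gives 3.61
- compound 2 `O=C(COc1cccc2ccccc12)N/N=C/C=C/c1ccccc1` gives 4.43
- compound 3 `C/C(=N\NC(=O)COc1cccc2ccccc12)c1ccccc1O` gives 3.08

Compound 2 stands highest of the three numbers, and its gaps to compound 1 and compound 3 both lie beyond the scatter. The next compound to be measured is compound 4 `O=C(COc1cccc2ccccc12)N/N=C/c1ccc(F)cc1`. It differs from compound 2 by 4-fluorophenyl in place of 2-phenylethenyl on a carbon with a double bond to nitrogen.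

Among the measured compounds shown here, only one measured step bears on this, and only indirectly. The step of a number 0.53 log units lower from compound 1 to compound 3 (beyond the scatter) is modest and beyond the scatter, and it also involves a swap of groups on a carbon with a double bond to nitrogen. Neither 4-fluorophenyl nor 2-phenylethenyl takes part in it, so it serves as a guide to size alone. The direction rests on the position of compound 2 at the top of the three numbers, and a fall of similar size is expected in this assay. The expected change is a number 0.48 log units lower from compound 2 to compound 4 (beyond the scatter). For compound 4 the estimated value is 3.95, with an expected range from 3.5 to 4.35.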

Compound 4, partition coefficient: 4.16
Compound 4: middle estimate off by 0.21 log units, on the low side, within the range that was stated.
By their numbers in this assay, from the lowest: compound 3; then compound 1; then compounds 4 and 2 (each within the scatter of the next).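

In this assay, the step at this position is a number 0.27 log units lower from compound 2 to compound 4 (within the scatter), so within the scatter, compound 2 and compound 4 cannot be told apart. Among the compounds shown here, this is the first step at a carbon with a double bond to nitrogen that stays within the scatter, unlike the step of a number 0.53 log units lower from compound 1 to compound 3 (beyond the scatter); here the double bond outside aromatic rings leaves, fluorine enters, and the group goes from 8 heavy atoms to 7, with no separable read-out. No measurement at hand gives a reason for this result.

Still open, on these data alone, is whether an amine, a carboxylic acid or a longer chain at this place would move the number beyond the scatter. Also open, as far as these compounds go, is how an unsubstituted phenyl would read, since loss of the double bond and entry of fluorine come together in this one step.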